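This account rests on a few compounds, and the source may have more. Where it says the series, first, only, none or still open, it means among the compounds named here.

Of the compounds shown here, three built on one shared core have been tested in a functional assay on U-87MG ATCC cells for antiproliferative activity against U-87 MG (Homo sapiens), read by MTT assay, with a stated time of 48 h, tested at 5 uM; on this read-out lower numbers stand for a stronger effect and higher numbers for a weaker effect at the one concentration tested. Compound 1 `COc1ccc(-c2nc(C)c(C(=O)CSc3nc(-c4ccc(OC)cc4)c(C#N)c(=O)[nH]3)s2)cc1` gives 97%. Compound 2 `Cc1nc(-c2ccc(Cl)cc2)sc1C(=O)CSc1nc(-c2ccc(Cl)c(Cl)c2)c(C#N)c(=O)[nH]1` gives 101%, and compound 3 `Cc1nc(-c2ccccc2)sc1C(=O)CSc1nc(-c2ccc(Cl)c(Cl)c2)c(C#N)c(=O)[nH]1` gives 98.6%. All three numbers sit close to the untreated level, so none of them holds back cell growth noticeably at this concentration. Compound 2 gives the highest of the three numbers, yet its gaps to compound 3 and to compound 1 lie within the usual scatter, so the three cannot be told apart. Going by the values given here, the one step between neighbouring structures, a number 2.4 percentage points lower from compound 2 to compound 3 (within the scatter), came with hydrogen in place of chloro on an aromatic carbon.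

Compound 4 `COc1ccc(-c2nc(SCC(=O)c3sc(-c4ccc(Cl)cc4)nc3C)[nH]c(=O)c2C#N)cc1OC` has not yet been measured. It differs from compound 2 in one place: 3,4-dimethoxyphenyl in place of 3,4-dichlorophenyl on an aromatic carbon. Among the compounds with values here, no measured step swaps this same group, so the only guide is compound 1, which also carries methoxy groups and gives 97%, indistinguishable from compound 2. Compound 4 is therefore expected to give 99%, between 90% and 108%. For compound 4 the expected step, a number 2 percentage points lower from compound 2 to compound 4 (within the scatter), is none beyond the scatter.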

Compound 4, a percentage reported as activity, at one concentration (the size of the read-out at that concentration, not a potency): 93.4%
Compound 4: the middle estimate sits 5.6 percentage points above what was measured; measured number inside the range.
By their numbers in this assay, from the lowest: compounds 4, 1, 3 and 2 (each within the scatter of the next).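

In this assay, putting 3,4-dimethoxyphenyl in place of 3,4-dichlorophenyl on this aromatic carbon of the shared core gives a number 7.6 percentage points lower from compound 2 to compound 4 (within the scatter), so compound 2 and compound 4 cannot be told apart. The earlier step concerned a chloro group at the other end of the molecule; this one shows that a large swap at this second site, a group with 2 hydrogen-bond acceptors for one with 0, also leaves no difference that stands out from the scatter. Nothing measured here offers an explanation for this result.

Going by these compounds, whether an amine, a morpholine ring or a carboxylic acid at this position would give a number clearly apart from these stays open. The compounds shown also leave open whether any of this series holds back cell growth at a higher concentration.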